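This account rests on a few compounds, and the source may have more. Where it says the series, first, only, none or still open, it means among the compounds named here.

Three compounds share one core and differ only in the group carried on a saturated chain carbon bound to an aromatic carbon. In a functional assay on the whole organism with Rattus norvegicus as the target, with a stated time of 4 h, at a dose of 40 mg/kg by the intraperitoneal route (on this read-out lower numbers stand for less inhibition and higher numbers for more inhibition at the one dose given (going by the name of the read-out)), compound 1 `CCOCc1c(C)nc2c(OCc3ccccc3)cccn12` gives 84%. Compound 2 `Cc1nc2c(OCc3ccccc3)cccn2c1CS(C)(=O)=O` gives 61% in this assay, and compound 3 `Cc1nc2c(OCc3ccccc3)cccn2c1CC(=O)O` gives 12% in this assay, the lowest of the three numbers. Compound 4 `Cc1nc2c(OCc3ccccc3)cccn2c1COC(=O)N(C)C` has not yet been measured; it differs from compound 3 by (dimethylcarbamoyl)oxy in place of carboxy on a saturated chain carbon bound to an aromatic carbon.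

Among the measured compounds shown here, the steps that bear on this change are those that placed carboxy at the same position: a number 72 percentage points lower from compound 1 to compound 3 (beyond the scatter) and a number 49 percentage points lower from compound 2 to compound 3 (beyond the scatter), both beyond the scatter, while a number 23 percentage points lower from compound 1 to compound 2 (beyond the scatter) was smaller. Every measured compound without carboxy at that position therefore sits well above compound 3, so removing carboxy is expected to raise inhibition in this assay by a large step, though the incoming group is new and the size is uncertain. Compound 4 is expected to give 60%, within a range from 30% to 85%. The expected step is a number 48 percentage points higher from compound 3 to compound 4 (beyond the scatter).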

Compound 4, a percentage reported as inhibition, in the whole organism at one dose (the size of the read-out at that dose, not a potency): 75%
For compound 4 the middle estimate is 15 percentage points below the measured one; low and high end bracket the measured number.
By their numbers in this assay, from the lowest: compound 3; then compound 2; then compounds 4 and 1 (each within the scatter of the next).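

In this assay, (dimethylcarbamoyl)oxy is a third group in place of carboxy that stands far above the carboxy compound, with a number 63 percentage points higher from compound 3 to compound 4 (beyond the scatter), so all three groups other than carboxy on this saturated chain carbon now give much more inhibition. The new group also separates from methylsulfonyl, with a number 14 percentage points higher from compound 2 to compound 4 (beyond the scatter), whereas the comparison with ethoxy, a number 9 percentage points lower from compound 1 to compound 4 (within the scatter), shows no real difference: the two groups joined to the chain carbon through oxygen cannot be told apart here. Nothing measured here accounts for these differences.

The compounds shown leave open how an amine, a hydroxyl or a longer chain on the same carbon would compare. Since each number comes from a single dose, they also leave open how inhibition would change at other doses.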